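The source may report more compounds than this note shows. Statements on the series, on what has been measured and on what is new or still open speak of the compounds shown alone.

Of the compounds shown here, three built on one shared core have been tested in an assay on cells with melanin-concentrating hormone receptor 1 (Homo sapiens) as the target, read by radioligand binding; a lower number here means a stronger inhibitor, a higher number a weaker inhibitor. Compound 1, `CC1CCC(Oc2cccc3ccc(N)nc23)C1`, gives 823 nM. Compound 2, `CC(C)=CCOc1cccc2ccc(N)nc12`, reaches only a limit of the measurement, > 2000 nM (the limit of > 2000 nM in this assay, at which 1 of the 3 values shown sits). Compound 3, `CCCCCOc1cccc2ccc(N)nc12`, gives 580 nM. Of the two numbers, compound 3 is separated from compound 1 by a 1.4-fold lower number from compound 1 to compound 3 (0.15 log units; within the scatter), which is within the scatter, so neither can be called the stronger. Among the measured compounds shown here, the step of an at least 2.4-fold higher number from compound 1 to compound 2 (0.38 log units; beyond the scatter) lies beyond the scatter, as does an at least 3.4-fold lower number from compound 2 to compound 3 (0.53 log units; beyond the scatter), the only steps that carry a real difference here.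

Compound 4, `CSCCOc1cccc2ccc(N)nc12`, has not yet been measured. It differs from compound 3 by methylsulfanyl in place of propyl on a saturated chain carbon, two bonds along the chain from an oxygen on an aromatic ring. The measured steps bear on this change only loosely: they swap whole groups on the oxygen, whereas this change shortens the chain and introduces a hydrogen-bond acceptor. The steps involving compound 2 show that departing from a plain saturated chain has so far weakened binding. Compound 4 is therefore expected to be a weaker inhibitor than compound 3, by an estimated 2.6-fold higher number from compound 3 to compound 4 (0.41 log units; beyond the scatter). Compound 4 is estimated at 1500 nM, with a range from 500 nM to 5000 nM.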

Compound 4, half-maximal inhibitory concentration: > 2000 nM
Compound 4: no number, only a limit (the forecaster's own chance of this, stated with the estimate: 35%); at least 1.3-fold (0.12 log units) between middle value and limit.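

Compound 4 gives no number in this assay, only a limit of the assay: the limit of > 2000 nM in this assay, at which 2 of the 4 values shown sit.

Until now the only substituent on the oxygen that lost binding was the unsaturated chain of compound 2, yet methylsulfanyl in place of propyl, on a saturated chain carbon, also costs binding, with an at least 3.4-fold higher number from compound 3 to compound 4 (0.53 log units; beyond the scatter) in this fully saturated chain. The loss also holds against the ring-bearing group, with an at least 2.4-fold higher number from compound 1 to compound 4 (0.38 log units; beyond the scatter) as the second readable step, while the step between compound 2 and compound 4 cannot be read, both being limits.

This change swaps propyl, with its three carbons, for methylsulfanyl, so the compounds shown cannot separate the sulfur from the shorter group. They also leave open whether a methoxy group or a hexyl chain at this place would keep binding close to that of compound 3.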